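A Nitro Group Added at the Assay Limit

A few compounds are considered here, and "the series" means these few. Any claim that something is new, unique, unknown or untested is made for them only; others in the source may bear on it.

In an ADME assay on SH-SY5Y cells (Homo sapiens) for cytotoxicity, read by MTT assay, with a stated time of 48 h (a lower number here means a stronger inhibitor, a higher number a weaker inhibitor), compound 3 (`COc1ccc(C(=O)/C=C/c2ccc(C(=O)Nc3ccccc3O)cc2)c(O)c1`) gives > 100000 nM as a limit of the assay and not a number. Compound 1 (`COc1ccc(C(=O)/C=C/c2ccc(C(=O)NCc3ccccc3)cc2)c(O)c1`) gives > 100000 nM as a limit too. Compound 2 (`COc1ccc(C(=O)/C=C/c2ccc(C(=O)Nc3ccccc3OC)cc2)c(O)c1`) also gives > 100000 nM as a limit. The whole picture so far is the limit of > 100000 nM in this assay, at which 3 of the 3 values shown sit, and nothing finer.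

Compound 4 (`COc1ccc(C(=O)/C=C/c2ccc(C(=O)Nc3cc([N+](=O)[O-])ccc3O)cc2)c(O)c1`) turns the 2-hydroxyphenyl of compound 3 into 2-hydroxy-5-nitrophenyl, with nitro in place of hydrogen on an aromatic carbon is the counted change. The measured steps that bear on this end of the molecule are a step that the two limits leave unreadable from compound 1 to compound 2 and a step that the two limits leave unreadable from compound 1 to compound 3 and a step that the two limits leave unreadable from compound 2 to compound 3 so none of them offers a size to carry over, and none adds a nitro group. In this assay the expected result is therefore a number no higher from compound 3 to compound 4 (the limit leaves the size open) with no shift beyond the scatter anticipated in either direction. Compound 4 is estimated at 100000 nM with an expected range from 30000 nM to 200000 nM and a report of a limit alone remains likely.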

Compound 4, half-maximal inhibitory concentration: > 100000 nM
Compound 4: no number, only a limit (the forecaster's own chance of this, stated with the estimate: 75%); the middle value sits exactly at the limit.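

Compound 4, like compound 1, compound 2 and compound 3, gives only a limit of the assay and not a number, so no step among these compounds can be read. The compounds shown leave open whether adding the nitro group shifts the value in this assay at all, as the whole picture remains: the limit of > 100000 nM in this assay, at which 4 of the 4 values shown sit.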